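Butylsulfanyl in Place of Benzyloxy: Tolerability Outlook

This account rests on a few compounds, and the source may have more. Where it says the series, first, only, none or still open, it means among the compounds named here.

Compound 1 `Nc1nc(OCc2ccccc2)c2ncn(/C=C3/CC3(CO)CO)c2n1` was tested in an ADME assay on CCRF-HSB-2 cells (Homo sapiens) for cytotoxicity, with a stated time of 7 days; a higher number here means that more compound is tolerated, a lower number that less compound is tolerated. Compound 1 gives only a limit of the assay there, > 20000 nM, so no number places it. Two relatives share its core. Compound 2 `CC(C)Nc1nc(N)nc2c1ncn2/C=C1/CC1(CO)CO` carries isopropylamino in place of benzyloxy on an aromatic carbon, and in this assay compound 2 likewise reaches only a limit, > 20000 nM. Compound 3 `CSc1nc(N)nc2c1ncn2/C=C1/CC1(CO)CO` carries methylsulfanyl in place of benzyloxy on an aromatic carbon, and in this assay compound 3 stops at a limit as well, > 100000 nM. The steps a step that the two limits leave unreadable from compound 1 to compound 2 and a step that the two limits leave unreadable from compound 1 to compound 3 therefore cannot be sized; the limit of > 20000 nM in this assay, at which 2 of the 3 values shown sit, and the limit of > 100000 nM in this assay, at which 1 of the 3 values shown sits, are all the evidence there is. Compound 4 `CCCCSc1nc(N)nc2c1ncn2/C=C1/CC1(CO)CO` is the next change: butylsulfanyl in place of benzyloxy on an aromatic carbon. Nothing measured points to a readable step in this assay in either direction, and the nearest relative, compound 3, sits at a limit. Compound 4 is therefore expected to give about 60000 nM in this assay, within 20000 nM to 200000 nM, most likely again as a limit. That means an expected step that the limit leaves unreadable from compound 1 to compound 4.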

Compound 4, half-maximal cytotoxic concentration: 89000 nM
The estimate for compound 4 lay 1.5-fold (0.17 log units) below the measured number; low and high end bracket the measured number.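

In this assay, within the data shown here, compound 4 gives an actual number, 89000 nM, which makes butylsulfanyl the first group at this position with a value that can be read rather than a limit. Going from methylsulfanyl to butylsulfanyl gives an at least 1.1-fold lower number from compound 3 to compound 4 (0.05 log units; that floor lies within the scatter); that floor lies within the usual scatter, so the data show no clear change, although the true step could be larger. The steps to compound 4 from the other two compounds cannot be read, because each of those compounds stands at a limit: the limit of > 20000 nM in this assay, at which 2 of the 4 values shown sit.

With a single number among limits, no trend with chain length on the sulfur can be stated. As far as these compounds go, it remains open whether a longer chain, such as octylsulfanyl, or a ring-bearing group, such as benzylsulfanyl, would give a number clearly lower than that of compound 4.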